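The source may report more compounds than this note shows. Statements on the series, on what has been measured and on what is new or still open speak of the compounds shown alone.

Measured compounds:
compound 1, `COc1cc(-c2cc(/C=C/C(=O)c3ccc(Cl)c(Cl)c3)[nH]n2)cc(OC)c1OC` — 57800 nM
compound 2, `COc1ccc(-c2cc(/C=C/C(=O)c3ccc(N)cc3)[nH]n2)cc1OC` — 7190 nM

Of the compounds shown here, two share a core and have been tested in a functional assay on SF-539 cells (Homo sapiens) for inhibition, read by sulforhodamine B assay, with a stated time of 48 h; a lower number here means that less compound is tolerated, a higher number that more compound is tolerated. Compound 1, with its structure `COc1cc(-c2cc(/C=C/C(=O)c3ccc(Cl)c(Cl)c3)[nH]n2)cc(OC)c1OC`, gives 57800 nM in this assay. Compound 2, `COc1ccc(-c2cc(/C=C/C(=O)c3ccc(N)cc3)[nH]n2)cc1OC`, gives 7190 nM. Compound 1 therefore stands as the higher of the two numbers, and the gap to compound 2 lies beyond the usual scatter; since the two compounds differ in more than one place, the two values alone say nothing about which difference carries that gap.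

Compound 3, `COc1cc(-c2cc(/C=C/C(=O)c3ccc(F)c(F)c3)[nH]n2)cc(OC)c1OC`, has not been measured in this assay. It differs from compound 1 in one place: 3,4-difluorophenyl in place of 3,4-dichlorophenyl on a carbonyl carbon. Among the compounds with values here, no measured pair shows what this exchange does, so the expectation for compound 3 rests on compound 1 alone. The step from compound 1 to compound 3 is expected to be small, a 1.3-fold lower number from compound 1 to compound 3 (0.11 log units; within the scatter), with the direction left open and likely not beyond the scatter. Compound 3 is accordingly expected to give about 45000 nM in this assay, within a range from 15000 nM to 130000 nM.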

Compound 3, concentration lethal to 50% of the cells: 70000 nM
Beside the measured number, compound 3's estimate is 1.6-fold (0.19 log units) below it; the measured number falls inside the stated range.
By their numbers in this assay, from the lowest: compound 2; then compounds 1 and 3 (each within the scatter of the next).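

In this assay, within the data shown here, putting 3,4-difluorophenyl in place of 3,4-dichlorophenyl on a carbonyl carbon gives a 1.2-fold higher number from compound 1 to compound 3 (0.08 log units; within the scatter) and is the first step that differs in only one place. At this position, then, the exchange of chlorine for fluorine on the same phenyl pattern, with the heavy-atom count of the group unchanged, leaves no readable difference in this read-out, and compound 1 and compound 3 stand together within the usual scatter. No independent evidence bears on this result.

What the compounds shown leave open is whether a different group on the same carbonyl carbon, such as an unsubstituted phenyl or a phenyl bearing a nitrile or a carboxylic acid, would move the number beyond the scatter, since this one step covers only an exchange between two dihalogenated phenyl groups. From the compounds shown here alone, also still open is which structural difference carries the gap between compound 1 and compound 2, as those two differ in more than one place and the new step does not separate those differences.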